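The source may report more compounds than this note shows. Statements on the series, on what has been measured and on what is new or still open speak of the compounds shown alone.

Measured so far:
Compound 1, `CCCCCCc1ccc2nc(N)sc2c1`: 7 mg/kg
Compound 2, `Nc1nc2ccc(C(=O)C(F)(F)F)cc2s1`: > 10 mg/kg, a limit of the assay
Compound 3, `C=CCn1c(=N)sc2cc(OC(F)(F)F)ccc21`: 7 mg/kg

All three were tested in a functional assay on the whole organism with Rattus norvegicus as the target; a lower number here means that less compound is needed, a higher number that more compound is needed for the effect. Compound 1 gives 7 mg/kg in this test. Compound 2 reaches only a limit of the test, not a number: the limit of > 10 mg/kg in this assay, at which 1 of the 3 values shown sits. Compound 3 gives 7 mg/kg, which is level with compound 1 at the digits shown; the two sit within the usual scatter of each other, so no order between them can be read from these numbers.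

Compound 4, `CSCCCn1c(=N)sc2cc(OC(F)(F)F)ccc21`, has not yet been measured. It differs from compound 3 in one place: 2-(methylsulfanyl)ethyl in place of vinyl on a saturated chain carbon bound to an aromatic nitrogen. Among the measured compounds shown here, no pair of measured compounds shows this same change, so there is no measured step to lean on. With nothing pointing in either direction, the step of no change at the digits printed from compound 3 to compound 4 (within the scatter) is expected to stay within the scatter. Compound 4 is therefore estimated at 7 mg/kg, with a range from 3 mg/kg to 15 mg/kg.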

Compound 4, dose for half-maximal effect: 4.2 mg/kg
Compound 4: the middle estimate sits 1.7-fold (0.22 log units) above what was measured, within the range that was stated.
By their numbers in this assay, from the lowest: compounds 4, 1 and 3 (each within the scatter of the next). At a limit, above all of these: compound 2.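

In this assay, among the compounds shown here, putting 2-(methylsulfanyl)ethyl in place of vinyl on a saturated chain carbon bound to an aromatic nitrogen gives a 1.7-fold lower number from compound 3 to compound 4 (0.22 log units; within the scatter), the only measured step at this place. It shows that this place can carry a group of 4 heavy atoms that holds a sulfur and 1 hydrogen-bond acceptor and has no double bond outside aromatic rings, with the number staying within the scatter of that for vinyl. Nothing measured here offers an explanation for this step.

This one step cannot separate the longer chain from the sulfur, as both enter together. It also leaves open whether an amine, a carboxylic acid or a longer chain in place of 2-(methylsulfanyl)ethyl would keep the number within the scatter.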